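Amide aryl variation on a shared core

This account rests on a few compounds, and the source may have more. Where it says the series, first, only, none or still open, it means among the compounds named here.

Measured so far:
compound 1 `O=C(Nc1cccc(-c2oc3cc(-c4ccc(F)cc4)ccc3c(=O)c2O)c1)c1ccc(Cl)cc1`: 10800 nM in a functional assay on A549 cells (Homo sapiens) for antiproliferative activity, read by CCK-8 assay, with a stated time of 72 h; on this read-out higher numbers stand for weaker inhibition and lower numbers for stronger inhibition
compound 2 `Cc1ccccc1C(=O)Nc1cccc(-c2oc3cc(-c4ccc(F)cc4)ccc3c(=O)c2O)c1`: 17600 nM in this assay

Compound 2 sits alongside compound 1 rather than apart from it: a 1.6-fold higher number from compound 1 to compound 2 (0.21 log units; within the scatter). Compound 3 `O=C(Nc1cccc(-c2oc3cc(-c4ccc(F)cc4)ccc3c(=O)c2O)c1)c1ccc(Br)cc1F` is the next member, differing from compound 2 by 4-bromo-2-fluorophenyl in place of 2-methylphenyl on a carbonyl carbon. For the measured compounds named here, the one measured step that bears on this, the swap of a halogenated phenyl for 2-methylphenyl on the carbonyl carbon between compound 1 and compound 2, stayed within the scatter, and compound 3 returns to a halogenated phenyl. No step beyond the scatter is therefore expected in this assay, in either direction, with a 1.5-fold lower number from compound 2 to compound 3 (0.17 log units; within the scatter). Compound 3 is estimated at 12000 nM, within 5000 nM to 30000 nM.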

Compound 3, half-maximal inhibitory concentration: 46100 nM
Compound 3: the middle estimate sits 3.8-fold (0.58 log units) below what was measured, and the stated range ends below it.
By their numbers in this assay, from the lowest: compounds 1 and 2 (each within the scatter of the next); then compound 3.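

For the compounds shown here, on the carbonyl carbon, the aryl group does change the result in this assay: 4-bromo-2-fluorophenyl gives a 2.6-fold higher number from compound 2 to compound 3 (0.42 log units; beyond the scatter) and a 4.3-fold higher number from compound 1 to compound 3 (0.63 log units; beyond the scatter), the first steps beyond the scatter. A halogenated phenyl alone therefore does not keep the number close to that of compound 1. No measured evidence accounts for these steps.

Still open, on these data alone, is whether the bromine, the fluorine or the pair carries the step, as compound 3 differs from compound 1 in both. Also open, as far as these compounds go, is how a pyridine ring or a saturated amine such as morpholine would read here.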